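The compounds below may be only part of what the source reports. "The series", "measured", "known", "first", "only" and "open" are said of these compounds alone.

In an ADME assay on the whole organism for inhibition, with Oryza sativa as the target, with a stated time of 4 days (on this read-out lower numbers stand for stronger inhibition and higher numbers for weaker inhibition), compound 1 `CCNc1nc(Cl)nc(N[C@H](C)c2ccccc2)n1` gives 14100 nM and compound 3 `CCN(CC)c1nc(Cl)nc(N[C@H](C)c2ccccc2)n1` gives 6310 nM. Compound 2 `CCCN(CC)c1nc(Cl)nc(N[C@@H](C)c2ccccc2)n1` gives 479 nM, the lowest of the three numbers and clearly beyond the scatter from both others. Compound 2 also carries the opposite configuration at the stereocentre bearing the phenyl ring, a feature it shares with compound 4 `CC[C@@H](C)Nc1nc(Cl)nc(N[C@@H](C)c2ccccc2)n1` but not with compound 1 or compound 3.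

The next change is (sec-butyl)amino in place of ethyl(propyl)amino on an aromatic carbon. Among the measured compounds shown here, the only measured step that bears on it is a 2.2-fold lower number from compound 1 to compound 3 (0.35 log units; beyond the scatter), a modest move on adding ethyl in place of the hydrogen on that nitrogen. Compound 4 runs the other way and regains a hydrogen on that nitrogen, so a modest rise in the number is expected, of similar or somewhat larger size. The evidence is thin: that single step comes from the other configuration, and no (sec-butyl)amino compound has been measured, so the range stays wide.

The expected change is a 2.1-fold higher number from compound 2 to compound 4 (0.32 log units; beyond the scatter), an estimate pointing to weaker inhibition. For compound 4, the estimated value is 1000 nM, with an expected range from 300 nM to 4000 nM.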

Compound 4, half-maximal inhibitory concentration: 9770 nM
Beside the measured number, compound 4's estimate is 9.8-fold (0.99 log units) below it, outside the stated range (above it).
By their numbers in this assay, from the lowest: compound 2; then compounds 3, 4 and 1 (each within the scatter of the next, the first and the last beyond it).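

In this assay, the group on the aromatic carbon opposite the ring nitrogen has a large influence, with a 20-fold higher number from compound 2 to compound 4 (1.31 log units; beyond the scatter) on (sec-butyl)amino in place of ethyl(propyl)amino; the entering group has 1 hydrogen-bond donor and 1 defined stereocentre, while the leaving group has 0 hydrogen-bond donors and no defined stereocentre. The only earlier step at this position, a 2.2-fold lower number from compound 1 to compound 3 (0.35 log units; beyond the scatter), is modest, so both steps now agree in direction, with the higher number on the compound that keeps a hydrogen on that nitrogen, but the new step is large and no compound shown goes against this direction. No measurement shown here accounts for the size of the new step.

From the compounds shown here alone, what remains open is which part of the change carries the step, since the hydrogen on the nitrogen, the chain and the added stereocentre all change at once; a straight butylamino group or an ethyl(butyl)amino group at this position would help to separate them. Going by these compounds, the role of the configuration at the stereocentre bearing the phenyl ring also stays open, as compound 2 and compound 3 differ in the chain as well.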